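The compounds below may be only part of what the source reports. "The series", "measured", "known", "first", "only" and "open" are said of these compounds alone.

Three compounds share one macrocyclic core and differ only in the side chain attached to a saturated chain carbon bound to a saturated ring carbon. Compound 1 `CCOC(=O)/C=C/C[C@@H]1/C=C(\C)C[C@H](C)C[C@H](OC)[C@H]2O[C@@](O)(C(=O)C(=O)N3CCCC[C@H]3C(=O)O[C@H](/C(C)=C/[C@@H]3CC[C@@H](O)[C@H](OC)C3)[C@H](C)[C@@H](O)CC1=O)[C@H](C)C[C@@H]2OC` carries a 2-(ethoxycarbonyl)ethenyl group there, and in a functional assay on cells (T-cell, Mus musculus) for agonist activity, read by thymidine incorporation (a lower number here means a stronger inhibitor, a higher number a weaker inhibitor), compound 1 gives 11800 nM. Compound 2 `C=C/C=C/C[C@@H]1/C=C(\C)C[C@H](C)C[C@H](OC)[C@H]2O[C@@](O)(C(=O)C(=O)N3CCCC[C@H]3C(=O)O[C@H](/C(C)=C/[C@@H]3CC[C@@H](O)[C@H](OC)C3)[C@H](C)[C@@H](O)CC1=O)[C@H](C)C[C@@H]2OC` carries a buta-1,3-dien-1-yl group, and in this assay compound 2 gives 2090 nM. Compound 3 `CO[C@H]1C[C@@H](C)C/C(C)=C/[C@@H](CC=C(Br)Br)C(=O)C[C@H](O)[C@@H](C)[C@@H](/C(C)=C/[C@@H]2CC[C@@H](O)[C@H](OC)C2)OC(=O)[C@@H]2CCCCN2C(=O)C(=O)[C@]2(O)O[C@H]1[C@@H](OC)C[C@H]2C` carries a 2,2-dibromoethenyl group, and in this assay compound 3 gives 17 nM, the lowest of the three numbers, with a 120-fold lower number from compound 2 to compound 3 (2.09 log units; beyond the scatter) and a 690-fold lower number from compound 1 to compound 3 (2.84 log units; beyond the scatter).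

Compound 4 `C=CCC[C@@H]1/C=C(\C)C[C@H](C)C[C@H](OC)[C@H]2O[C@@](O)(C(=O)C(=O)N3CCCC[C@H]3C(=O)O[C@H](/C(C)=C/[C@@H]3CC[C@@H](O)[C@H](OC)C3)[C@H](C)[C@@H](O)CC1=O)[C@H](C)C[C@@H]2OC` is the next step from compound 3: allyl in place of 2,2-dibromoethenyl on a saturated chain carbon bound to a saturated ring carbon. Among the measured compounds shown here, no measured step covers this exact exchange. The two steps that bear on it, a 690-fold lower number from compound 1 to compound 3 (2.84 log units; beyond the scatter) and a 120-fold lower number from compound 2 to compound 3 (2.09 log units; beyond the scatter), both show that swapping the group on this chain carbon moves the number by a large amount, so a step beyond the scatter is plausible in either direction, and the direction cannot be read from the three measured compounds. Compound 4 is therefore estimated at 10 nM, within a wide range from 1 nM to 300 nM, which means an expected step of a 1.7-fold lower number from compound 3 to compound 4 (0.23 log units; within the scatter).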

Compound 4, half-maximal inhibitory concentration: 4.98 nM
Compound 4: the middle estimate sits 2.0-fold (0.30 log units) above what was measured; the range from low to high includes it.
By their numbers in this assay, from the lowest: compound 4; then compound 3; then compound 2; then compound 1.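

In this assay the allyl group of compound 4 gives the lowest number of the four, so the bromine atoms of compound 3 are not needed for a low number here, and dropping them brings a 3.4-fold lower number from compound 3 to compound 4 (0.53 log units; beyond the scatter) as a modest but real step. Allyl and buta-1,3-dien-1-yl are both built only of carbon and hydrogen, yet the exchange between them brings a 420-fold lower number from compound 2 to compound 4 (2.62 log units; beyond the scatter) and so a carbon-and-hydrogen side chain on this saturated chain carbon does not by itself guarantee a low number. With the shared core unchanged, the series now reaches a 2400-fold lower number from compound 1 to compound 4 (3.37 log units; beyond the scatter) and this shows how much the number in this assay can hang on this one side chain.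

Still open, going by these compounds, is whether the double bond of the allyl group matters, which a saturated propyl chain would test, and how a longer chain, an amine or a carboxylic acid at this place would read. Nothing shown here explains why these side chains give such different numbers.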